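Chloro on the Benzoyl Ring of Compound 1

The compounds below may be only part of what the source reports. "The series", "measured", "known", "first", "only" and "open" are said of these compounds alone.

In a functional assay on PC-3 cells (Homo sapiens) for cytotoxicity, read by sulforhodamine B assay, with a stated time of 72 h (a lower number here means a stronger inhibitor of growth, a higher number a weaker inhibitor of growth), the measured compounds stand thus:
Compound 1 `O=C(Nc1ccccc1C(F)(F)F)C1CCc2ccccc2N1C(=O)c1ccccc1` gives 5560 nM.
Compound 2 `O=C(Nc1ccccc1O)C1CCc2ccccc2N1C(=O)c1ccccc1` gives 5690 nM.
Compound 3 `O=C(Nc1cc(C(F)(F)F)cc(C(F)(F)F)c1)C1CCc2ccccc2N1C(=O)c1ccccc1` gives 3500 nM.

Compound 1 holds the second highest of the three numbers; its nearest neighbour is compound 2, its furthest compound 3, and both gaps lie within the scatter. Compound 4 `O=C(Nc1ccccc1C(F)(F)F)C1CCc2ccccc2N1C(=O)c1ccc(Cl)cc1` is the next compound: chloro in place of hydrogen on an aromatic carbon. Within the data shown here, the one measured step, a 1.0-fold higher number from compound 1 to compound 2 (0.01 log units; within the scatter), alters the anilide side and not the benzoyl, so no measured step bears on this change, and the three measured values sit within the scatter of one another. He therefore expects no step beyond the scatter, a 1.1-fold lower number from compound 1 to compound 4 (0.05 log units; within the scatter). Compound 4 is estimated at 5000 nM, between 2000 nM and 12000 nM.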

Compound 4, concentration for 50% growth inhibition: 786 nM
Estimate against measurement, compound 4: 6.4-fold (0.80 log units) above, and the stated range ends above it.
By their numbers in this assay, from the lowest: compound 4; then compounds 3, 1 and 2 (each within the scatter of the next).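

On the benzoyl ring of compound 1, chloro in place of hydrogen, on an aromatic carbon para to a large group, gives a 7.1-fold lower number from compound 1 to compound 4 (0.85 log units; beyond the scatter) in this assay. The earlier compounds, whose one listed step altered the anilide side and stayed within the scatter, showed no step beyond it. Nothing measured here accounts for this step.

The compounds shown leave open whether fluoro, methoxy or an amine at this place would do the same. They also leave open whether chloro would give a similar step on compound 2 or compound 3.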